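Swapping a propyl tail for 4-chlorophenyl on a shared core

The compounds below may be only part of what the source reports. "The series", "measured", "known", "first", "only" and "open" are said of these compounds alone.

Compound 1, `CCCCOc1c(OC)c(OC)cc2c1C(=O)[C@]1(OC)C=C[C@H]2N(C(=O)OC)N1C(=O)OC`, was tested in an ADME assay on KB cells (Homo sapiens) for cytotoxicity; a lower number here means that less compound is needed, a higher number that more compound is needed for the effect. In that assay compound 1 gives > 300 ug/mL, which is a limit of the assay and not a number. Compound 2, `COc1cc2c(c(O)c1OC)C(=O)[C@]1(OC)C=C[C@H]2N(C(=O)OCC(C)C)N1C(=O)OCC(C)C`, likewise gives only the limit > 300 ug/mL in this assay. Compound 3, `CCOC(=O)N1[C@@H]2C=C[C@@](OC)(C(=O)c3c2cc(OC)c(OC)c3OCC)N1C(=O)OCC`, gives the limit > 300 ug/mL as well. So compound 1 stands at the limit of > 300 ug/mL in this assay, at which 3 of the 3 values shown sit, with nothing to rank it against. Compound 4, `COC(=O)N1[C@@H]2C=C[C@@](OC)(C(=O)c3c2cc(OC)c(OC)c3OCc2ccc(Cl)cc2)N1C(=O)OC`, is not yet measured; it differs from compound 1 by 4-chlorophenyl in place of propyl on a saturated chain carbon bound to an oxygen on an aromatic ring. Within the data shown here, with no measured step to lean on, the expected move an at least 1.2-fold lower number from compound 1 to compound 4 (0.07 log units; that floor lies within the scatter) is small and probably again not resolved by the assay. Compound 4 is therefore estimated at 250 ug/mL, within 60 ug/mL to 300 ug/mL.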

Compound 4, concentration for half-maximal effect: 55.9 ug/mL
Compound 4: the middle estimate sits 4.5-fold (0.65 log units) above what was measured; measured number below the stated range.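

Replacing propyl with 4-chlorophenyl on a saturated chain carbon bound to an oxygen on an aromatic ring gives an at least 5.3-fold lower number from compound 1 to compound 4 (0.72 log units; beyond the scatter), so this position on the shared core can shift the read-out in this assay. Compound 4 is the only compound shown to give a number rather than a limit: the limit of > 300 ug/mL in this assay, at which 3 of the 4 values shown sit.

Going by these compounds, it stays open whether the ring or the chlorine carries this step, which an unsubstituted phenyl in the same place would separate. On these data alone, how an amine on that chain would read also stays open.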